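Aryl sulfone replacement from compound 3 to compound 4

A few compounds are considered here, and "the series" means these few. Any claim that something is new, unique, unknown or untested is made for them only; others in the source may bear on it.

Compound 3 `Cc1ccc2ncc(S(=O)(=O)c3cc(Cl)cc(Cl)c3)c(N3CCC(C)CC3)c2c1` stands second highest of the three measured numbers in an assay on isolated protein for displacement of a labelled ligand from metabotropic glutamate receptor 5 (Homo sapiens), with a stated time of 60 min, tested at 1 uM (on this read-out higher numbers stand for more inhibition at the one concentration tested (going by the name of the read-out) and lower numbers for less inhibition), at 75%. Compound 1 `COc1ccc(S(=O)(=O)c2cnc3ccc(C)cc3c2N2CCC(C)CC2)cc1` gives 62% and compound 2 `COc1ccc(S(=O)(=O)c2cnc3ccc(C)cc3c2N2CCC(C)CC2)cc1Cl` gives 93%. The step of a number 31 percentage points higher from compound 1 to compound 2 (beyond the scatter) came with chloro in place of hydrogen on an aromatic carbon, while the steps of a number 13 percentage points higher from compound 1 to compound 3 (beyond the scatter) and a number 18 percentage points lower from compound 2 to compound 3 (beyond the scatter) both concern the aryl group on the sulfonyl sulfur. Compound 4 `Cc1ccc2ncc(S(=O)(=O)c3cccc(C#N)c3)c(N3CCC(C)CC3)c2c1` differs from compound 3 by 3-cyanophenyl in place of 3,5-dichlorophenyl on a sulfonyl sulfur. Among the measured compounds shown here, no measured step covers a cyanophenyl group; the two steps that change the aryl group on the sulfonyl sulfur were modest in either direction, so a modest fall or no change beyond the scatter is expected, with wide uncertainty. Compound 4 is therefore estimated at 60% (range 35% to 85%), an expected step of a number 15 percentage points lower from compound 3 to compound 4 (beyond the scatter).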

Compound 4, a percentage reported as inhibition, at one concentration (the size of the read-out at that concentration, not a potency): 52%
Estimate against measurement, compound 4: 8 percentage points above; the measured number falls inside the stated range.
By their numbers in this assay, from the lowest: compounds 4 and 1 (each within the scatter of the next); then compound 3; then compound 2.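

Both chlorine-bearing aryl groups on the sulfonyl sulfur outdo 3-cyanophenyl, with a number 23 percentage points lower from compound 3 to compound 4 (beyond the scatter) and a number 41 percentage points lower from compound 2 to compound 4 (beyond the scatter) as the steps. Replacing 4-methoxyphenyl with 3-cyanophenyl gives a number 10 percentage points lower from compound 1 to compound 4 (within the scatter) and so does not separate these two groups. No measurement at hand offers a cause for these steps.

The compounds shown do not separate the entry of the nitrile from the loss of chlorine in the change from 3,5-dichlorophenyl. Also open, going by these compounds, is how a plain phenyl, or a phenyl carrying an amine or a carboxylic acid, would read on the sulfonyl sulfur.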